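Swapping the unsaturated amide chain on a thienopyrimidine anilide

This account rests on a few compounds, and the source may have more. Where it says the series, first, only, none or still open, it means among the compounds named here.

Measured so far:
compound 1, `COc1ccc(Nc2nc(Oc3cccc(NC(=O)/C=C/C(C)C)c3)c3sccc3n2)cc1` — 25200 nM
compound 2, `COc1cccc(Nc2nc(Oc3cccc(NC(=O)C=C(C)C)c3)c3sccc3n2)c1` — 25800 nM

Both compounds were tested in a functional assay on A-431 cells (Homo sapiens) for inhibition, read by MTT assay, with a stated time of 72 h; a higher number here means a weaker inhibitor, a lower number a stronger inhibitor. Compound 2 gives 25800 nM, and compound 1 gives 25200 nM; the two numbers lie within the usual scatter of each other, so neither stands apart.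

Compound 3, `COc1cccc(Nc2nc(Oc3cccc(NC(=O)/C=C/C(C)C)c3)c3sccc3n2)c1`, has not yet been measured. It differs from compound 2 in one place: 3-methylbut-1-en-1-yl in place of 2-methylprop-1-en-1-yl on a carbonyl carbon. Among the compounds with values here, no measured pair shows this change alone. Within the data shown here, with only two weak compounds in hand, no shift beyond the scatter is expected. Compound 3 is estimated at 25000 nM, between 9000 nM and 70000 nM, a step of a 1.0-fold lower number from compound 2 to compound 3 (0.01 log units; within the scatter) in this assay.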

Compound 3, half-maximal inhibitory concentration: 23400 nM
Estimate against measurement, compound 3: 1.1-fold (0.03 log units) above; the range from low to high includes it.
By their numbers in this assay, from the lowest: compounds 3, 1 and 2 (each within the scatter of the next).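

In this assay putting 3-methylbut-1-en-1-yl in place of 2-methylprop-1-en-1-yl on the carbonyl carbon gives a 1.1-fold lower number from compound 2 to compound 3 (0.04 log units; within the scatter) and so stays within the scatter. Putting 3-methoxyphenyl in place of 4-methoxyphenyl on the nitrogen gives a 1.1-fold lower number from compound 1 to compound 3 (0.03 log units; within the scatter) and also stays within the scatter, so neither change separates these compounds. Nothing available explains why these changes leave the numbers so close. Still open, from the compounds shown here alone, is whether a dimethylamine-bearing chain or a longer carbon chain in this place would give a step beyond the scatter.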